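Aryl replacement on the saturated ring carbon, second step

This account rests on a few compounds, and the source may have more. Where it says the series, first, only, none or still open, it means among the compounds named here.

Compound 1 `COc1ccc(C2OC(c3cc(OC)c(OC)c(OC)c3)=NN2C(C)=O)c(OC)c1` and compound 2 `COc1cc(C2=NN(C(C)=O)C(c3ccccc3C(F)(F)F)O2)cc(OC)c1OC` share one core and differ only in the aryl group on a saturated ring carbon. In a functional assay on BGC-823 cells (Homo sapiens) for antiproliferative activity, read by MTT assay, tested at 1 uM (on this read-out lower numbers stand for a weaker effect and higher numbers for a stronger effect at the one concentration tested), compound 1 gives 6.3% and compound 2 gives 31.8%. Going by the values given here, the single measured step, a number 25.5 percentage points higher from compound 1 to compound 2 (beyond the scatter), leaves compound 2 as the higher of the two numbers, beyond the scatter. Compound 3 `COc1cc(C2=NN(C(C)=O)C(c3ccc(F)cc3)O2)cc(OC)c1OC` carries the change (4-fluorophenyl in place of 2-(trifluoromethyl)phenyl on a saturated ring carbon). The measured step concerns the same saturated ring carbon but a different pair of aryl groups, so it bears on compound 3 only loosely: it shows that an exchange at this position can move the read-out by a modest amount. Among the compounds with values here, no measured step involves 4-fluorophenyl, and nothing shows whether this exchange moves the number up or down. The expected step of a number 13.8 percentage points lower from compound 2 to compound 3 (beyond the scatter) is a modest fall, held with wide uncertainty. Compound 3 is estimated at 18%, in the range 3% to 40%.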

Compound 3, a percentage reported as inhibition, at one concentration (the size of the read-out at that concentration, not a potency): -0.4%
Compound 3: the middle estimate sits 18.4 percentage points above what was measured; measured number outside the range, below it.
By their numbers in this assay, from the lowest: compounds 3 and 1 (each within the scatter of the next); then compound 2.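

In this assay, 4-fluorophenyl in place of 2-(trifluoromethyl)phenyl on the saturated ring carbon gives a number 32.2 percentage points lower from compound 2 to compound 3 (beyond the scatter), a large step where the earlier one was modest, so the read-out at this position is not simply carried by any fluorine-bearing phenyl group. With a number 6.7 percentage points lower from compound 1 to compound 3 (within the scatter), the 4-fluorophenyl and 2,4-dimethoxyphenyl groups cannot be told apart in this read-out, which leaves compound 2 as the only one of the three that stands apart from the others. Nothing at hand accounts for the gap between these aryl groups.

2-(Trifluoromethyl)phenyl and 4-fluorophenyl differ in both the substituent and its place on the phenyl ring, so the two changes remain unseparated; 4-(trifluoromethyl)phenyl and 2-fluorophenyl would divide them. As far as these compounds go, how a phenyl group carrying an amine or a carboxylic acid reads on this carbon also remains open.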